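A few compounds are considered here, and "the series" means these few. Any claim that something is new, unique, unknown or untested is made for them only; others in the source may bear on it.

Compound 1 `COc1cc(C(c2cc(OC)c(OC)c(OC)c2)[C@@H]2COC(=O)[C@H]2C)cc(OC)c1O`: 151000 nM
Compound 2 `COc1cc(C(c2cc(OC)c(OC)c(OC)c2)[C@@H]2COC(=O)[C@H]2C)cc(O)c1OC`: a limit only, > 231000 nM

In a functional assay on WI-38 VA13 cells (Homo sapiens) for cytotoxicity (on this read-out lower numbers stand for stronger inhibition and higher numbers for weaker inhibition), compound 1 gives 151000 nM. Compound 2 reaches only the limit of the assay, > 231000 nM, and so has no number of its own; it stands at the limit of > 231000 nM in this assay, at which 1 of the 2 values shown sits. Compound 3 `COc1cc(C(c2cc(OC)c(OC)c(OC)c2)[C@@H]2COC(=O)[C@H]2C)cc(OC)c1OC` differs from compound 2 in one place: methyl in place of hydrogen on an oxygen on an aromatic ring. For the measured compounds named here, no measured pair carries this change, so neither size nor direction of the step can be read from the data. Compound 3 is expected to remain weak, with an estimated step of an at least 1.1-fold lower number from compound 2 to compound 3 (0.06 log units; that floor lies within the scatter). Compound 3 is estimated at 200000 nM, between 80000 nM and 500000 nM.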

Compound 3, half-maximal inhibitory concentration: 120000 nM
Beside the measured number, compound 3's estimate is 1.7-fold (0.22 log units) above it; the measured number falls inside the stated range.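

In this assay the hydroxy to methoxy change on compound 1 gives a 1.3-fold lower number from compound 1 to compound 3 (0.10 log units; within the scatter) and so separates the two compounds by no more than the usual scatter. A free hydroxy at that place is therefore not needed for the number seen with compound 1. Compound 2 stands at > 231000 nM as a limit of the assay and not a number. On these data alone, from that limit, the same change at its own hydroxy reads only as an at least 1.9-fold lower number from compound 2 to compound 3 (0.28 log units; that floor lies within the scatter) and its true size stays unknown.

As far as these compounds go, what an amine or a longer chain such as ethoxy would do on these ring positions remains open. So does whether any change to the shared core would move the number at all.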